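The source may hold more compounds than are shown below. What is called first, only, known or untested is meant among the compounds shown, and "the series" means these compounds.

Measured compounds:
Compound 1, `Cc1cc2[nH]nc(N)c2c(=O)[nH]1`: 6% in an assay on isolated protein for inhibition of ribosomal protein S6 kinase alpha-1 (Homo sapiens), read by mobility shift assay, tested at 30 uM; on this read-out lower numbers stand for less inhibition and higher numbers for more inhibition at the one concentration tested (going by the name of the read-out)
Compound 2, `CC(C)(C)c1cc2[nH]nc(N)c2c(=O)[nH]1`: 22%
Compound 3, `Cc1cc2nn(-c3ccccc3)c(N)c2c(=O)[nH]1`: -11%

Of the compounds shown here, three have been measured so far, and only one pair among them differs in a single place. Compound 1 and compound 2 share a core and differ by tert-butyl in place of methyl on an aromatic carbon. In this assay this change gave a number 16 percentage points higher from compound 1 to compound 2 (beyond the scatter), a step that lies beyond the usual scatter of the measurement but remains modest in size.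

Compound 3 carries a different core from compound 1; the difference between the two cores is not broken down here. Compound 3 gives the lowest of the three numbers. Its nearest neighbour is compound 1, and its furthest is compound 2, both of them beyond the scatter above it.

Compound 4, `CC(C)(C)c1cc2nn(-c3ccccc3)c(N)c2c(=O)[nH]1`, has not yet been measured. It differs from compound 3 by tert-butyl in place of methyl on an aromatic carbon, and its place description matches that of the change from compound 1 to compound 2 word for word, so the two changes are the same.

The expectation for compound 4 therefore rests on a single precedent, the step seen in compound 1 and compound 2. The step is expected to be a number 16 percentage points higher from compound 3 to compound 4 (beyond the scatter) because a number 16 percentage points higher from compound 1 to compound 2 (beyond the scatter) was seen once before in the same place. Compound 4 is accordingly estimated at 5%, with a likely range from -10% to 20%.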

Compound 4, a percentage reported as inhibition, at one concentration (the size of the read-out at that concentration, not a potency): 5%
Compound 4: the middle estimate sits on the measured number at the digits printed; the range from low to high includes it.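

In this assay, tert-butyl in place of methyl on an aromatic carbon gave a number 16 percentage points higher from compound 3 to compound 4 (beyond the scatter), and set beside the earlier step on the other core, the change carried over with no difference in size that could be told from the scatter: the same change on two cores in this assay, a number 16 percentage points higher (beyond the scatter) from compound 1 to compound 2 and a number 16 percentage points higher (beyond the scatter) from compound 3 to compound 4, 0 percentage points apart, within the scatter of two such steps

Within these four compounds, then, the change can be treated as a step that moves the number by the same amount on either core, even though the two cores start from different numbers. This does not show that the step would hold on any further core, since it rests on just two pairs, and it says nothing of why the two steps agree or of potency, as each number is a percentage read at a single concentration.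

The compounds shown leave open what other groups on the same carbon would do in this assay, for instance an ethyl group, a longer chain, an amine or a carboxylic acid. They also leave open whether the step seen with tert-butyl would persist on a third core.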